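Swapping Trifluoromethyl for tert-Butyl on the Benzyl Arm

The compounds below may be only part of what the source reports. "The series", "measured", "known", "first", "only" and "open" are said of these compounds alone.

Compound 1 `O=C(NO)c1ccc(N(Cc2ccc(C(F)(F)F)cc2)C(=O)CN(Cc2ccccc2C(F)(F)F)S(=O)(=O)c2ccc(F)c(F)c2)cc1` was tested in an assay on Sf9 cells for inhibition of histone deacetylase 11 (Homo sapiens), read by mobility shift assay (on this read-out lower numbers stand for stronger inhibition and higher numbers for weaker inhibition), and gave 396 nM. Among the two numbers recorded in this assay it is the higher one; its only neighbour is compound 2 `O=C(NO)c1ccc(N(Cc2ccc(C(F)(F)F)cc2)C(=O)CN(Cc2ccccc2C(F)(F)F)S(=O)(=O)c2ccc(F)cc2)cc1`, which in this assay gives 304 nM, and the step of a 1.3-fold lower number from compound 1 to compound 2 (0.11 log units; within the scatter) separates the two, so they cannot be told apart on these data.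

Compound 3 `CC(C)(C)c1ccc(CN(C(=O)CN(Cc2ccccc2C(F)(F)F)S(=O)(=O)c2ccc(F)c(F)c2)c2ccc(C(=O)NO)cc2)cc1` has not yet been measured. It differs from compound 1 in one place: tert-butyl in place of trifluoromethyl on an aromatic carbon. Among the compounds with values here, the single measured step, from compound 1 to compound 2, concerns the loss of a fluoro from the sulfonyl aryl ring and stays within the scatter; it does not touch the benzyl arm where the trifluoromethyl sits, so no measured step bears on the present change. With nothing to indicate a shift in either direction, the step of a 1.0-fold higher number from compound 1 to compound 3 (0.00 log units; within the scatter) is expected to remain within the scatter. Compound 3 is therefore estimated to give 400 nM in this assay, with a likely range from 150 nM to 1100 nM.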

Compound 3, half-maximal inhibitory concentration: 254 nM
Compound 3: the middle estimate sits 1.6-fold (0.20 log units) above what was measured; low and high end bracket the measured number.
By their numbers in this assay, from the lowest: compounds 3, 2 and 1 (each within the scatter of the next).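

In this assay, the exchange on the benzyl arm gives a 1.6-fold lower number from compound 1 to compound 3 (0.19 log units; within the scatter), so replacing the trifluoromethyl group of 4-(trifluoromethyl)benzyl with tert-butyl, which has the same number of heavy atoms but four carbons in place of one carbon and three fluorines, produces no difference that can be told from the scatter. Within the data shown here, the earlier pair varied only the sulfonyl aryl ring, so this is the first reading at this aromatic carbon on the other side of the molecule, and it shows that inhibition at this level does not depend on trifluoromethyl specifically being there. No available evidence explains why the two groups read alike in this assay.

Two groups that both lack a ring and any hydrogen-bond donor or acceptor say little about how a group of a different kind would read here, such as an amine or a carboxylic acid on the same aromatic carbon. Also open is whether tert-butyl would read the same alongside the sulfonyl aryl ring of compound 2, since this exchange is shown only on the core of compound 1.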